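A few compounds are considered here, and "the series" means these few. Any claim that something is new, unique, unknown or untested is made for them only; others in the source may bear on it.

In a functional assay on HepG2 cells (Homo sapiens) for antiproliferative activity, read by CCK-8 assay, with a stated time of 72 h, tested at 8 uM (on this read-out higher numbers stand for a stronger effect at the one concentration tested and lower numbers for a weaker effect), compound 3 `CCCCn1cnc2c(NCc3ccc(C(=O)Nc4ccccc4N)cc3)nc(Cl)nc21` gives 19.6%, the lowest of the three numbers recorded: compound 1 `COC(CCn1cnc2c(NCc3ccc(C(=O)Nc4ccccc4N)cc3)nc(Cl)nc21)OC` gives 34.2% and compound 2 `CCC(C)n1cnc2c(NCc3ccc(C(=O)Nc4ccccc4N)cc3)nc(Cl)nc21` gives 65%. Compound 4 `CC(C)n1cnc2c(NCc3ccc(C(=O)Nc4ccccc4N)cc3)nc(Cl)nc21` differs from compound 3 by isopropyl in place of butyl on an aromatic nitrogen. The step that bears most on this change is a number 45.4 percentage points lower from compound 2 to compound 3 (beyond the scatter), which ran the opposite way, from sec-butyl to butyl on the same nitrogen. The step of a number 30.8 percentage points higher from compound 1 to compound 2 (beyond the scatter) also ended at sec-butyl with the highest number seen. Returning toward a shorter group on that nitrogen, compound 4 is therefore expected to show a step of a number 30.4 percentage points higher from compound 3 to compound 4 (beyond the scatter), an increase in this assay beyond the scatter. The estimate for compound 4 is 50%, with a range from 25% to 72%.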

Compound 4, a percentage reported as inhibition, at one concentration (the size of the read-out at that concentration, not a potency): 74.4%
Compound 4: the middle estimate sits 24.4 percentage points below what was measured; the whole stated range lies below it.
By their numbers in this assay, from the lowest: compound 3; then compound 1; then compounds 2 and 4 (each within the scatter of the next).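

In this assay, isopropyl in place of butyl on the aromatic nitrogen gives a number 54.8 percentage points higher from compound 3 to compound 4 (beyond the scatter) and shows that the shorter branched group, not only sec-butyl, stands well clear of butyl. Hydrogen in place of methyl on the saturated chain carbon gives a number 9.4 percentage points higher from compound 2 to compound 4 (within the scatter) and leaves sec-butyl and isopropyl indistinguishable here, while isopropyl in place of 3,3-dimethoxypropyl gives a number 40.2 percentage points higher from compound 1 to compound 4 (beyond the scatter) and sets isopropyl clearly apart from that chain too. Nothing given here explains these differences. Going by these compounds, whether cyclopropyl, tert-butyl or a shorter chain such as ethyl on that nitrogen would hold this level remains open.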